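The compounds below may be only part of what the source reports. "The series", "measured", "known", "first", "only" and "open" are said of these compounds alone.

Measured compounds. Compound 1 `CC(C)[C@H](NC(=O)COc1cccc2ccccc12)C(=O)N[C@@H](CC(=O)O)C(=O)CSc1nccn1C`: in a functional assay on Jurkat cells (Homo sapiens) for inhibition (a higher number here means a weaker inhibitor, a lower number a stronger inhibitor), compound 1 gives > 200000 nM, which is a limit of the assay. Compound 2 `CC(C)[C@H](NC(=O)COc1cccc2ccccc12)C(=O)N[C@@H](CC(=O)O)C(=O)CSc1nncn1C`: in this assay compound 2 gives > 200000 nM, also a limit. Compound 3 `CC(C)[C@H](NC(=O)COc1cccc2ccccc12)C(=O)N[C@@H](CC(=O)O)C(=O)CSc1nc2ccccc2o1`: in this assay compound 3 gives > 200000 nM, again a limit.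

Compound 3 thus stands where every value in the set stands, at the limit of > 200000 nM in this assay, at which 3 of the 3 values shown sit. The steps that exchange the group on the sulfur, a step that the two limits leave unreadable from compound 1 to compound 3 and a step that the two limits leave unreadable from compound 2 to compound 3, bear on the next change, but both are unreadable, so no size or direction can be drawn from them.

Compound 4 `CC(C)[C@H](NC(=O)COc1cccc2ccccc12)C(=O)N[C@@H](CC(=O)O)C(=O)CSc1nccc(C(F)(F)F)n1` differs from compound 3 as follows: 4-(trifluoromethyl)pyrimidin-2-yl in place of 1,3-benzoxazol-2-yl on a sulfur. With three variants on the sulfur all at the limit, compound 4 is expected to remain there as well, the step that the limit leaves unreadable from compound 3 to compound 4 being an expectation of no readable change. Compound 4 is therefore estimated at 300000 nM, range 50000 nM to 2000000 nM.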

Compound 4, half-maximal inhibitory concentration: > 200000 nM
Compound 4 ended at the assay's limit; the forecaster's own chance of this, stated with the estimate: 80%; the middle value is on the limit's open side.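

In this assay compound 4 gives > 200000 nM, a limit, so the steps to it from compound 1, compound 2 and compound 3 cannot be read. The compounds shown leave open whether any group on the sulfur gives a readable inhibition value: the limit of > 200000 nM in this assay, at which 4 of the 4 values shown sit.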